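The source may hold more compounds than are shown below. What is called first, only, known or untested is meant among the compounds shown, and "the series" means these compounds.

Measured so far:
compound 1, `CS(=O)(=O)c1ccc(Cc2nnc3n2N=C(c2ccc(-c4ccccc4)cc2)CS3)cc1`: 58.2%
compound 2, `CS(=O)(=O)c1ccc(Cc2nnc3n2N=C(c2cc(Cl)sc2S(N)(=O)=O)CS3)cc1`: 22.8%
compound 3, `CS(=O)(=O)c1ccc(Cc2nnc3n2N=C(c2cc4ccccc4c(=O)o2)CS3)cc1`: 22.4%

These three share one core and differ only in the group attached to the carbon with a double bond to nitrogen. In a functional assay on RAW264.7 cells (Mus musculus) for cytotoxicity, read by MTT assay, with a stated time of 48 h, tested at 12.5 uM (a higher number here means a stronger effect of the compound at the concentration tested, a lower number a weaker effect), compound 2 stands second highest of the three numbers. Its nearest neighbour is compound 3, whose value lies within the scatter, so the two cannot be told apart. Compound 1 lies far above both, beyond the scatter.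

The next compound, compound 4, `CS(=O)(=O)c1ccc(Cc2nnc3n2N=C(c2ccc(O)c(C(N)=O)c2)CS3)cc1`, differs from compound 2 in one place:

3-carbamoyl-4-hydroxyphenyl in place of 5-chloro-2-sulfamoylthiophen-3-yl on a carbon with a double bond to nitrogen

Going by the values given here, no step between measured compounds involving this change is known, so the expectation rests on the three values alone. Because compound 2 gives 22.8% and compound 3 gives 22.4%, both carrying groups rich in hydrogen-bond donors and acceptors, a step from compound 2 to compound 4 of modest size, in either direction and possibly none beyond the scatter, is expected: a number 7.2 percentage points higher from compound 2 to compound 4 (within the scatter). Compound 4 is thus estimated at 30%, with a range from 10% to 55%.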

Compound 4, a percentage reported as activity, at one concentration (the size of the read-out at that concentration, not a potency): 24.8%
Estimate against measurement, compound 4: 5.2 percentage points above, and the stated range covers the measured number.
By their numbers in this assay, from the lowest: compounds 3, 2 and 4 (each within the scatter of the next); then compound 1.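

In this assay, placing 3-carbamoyl-4-hydroxyphenyl where 5-chloro-2-sulfamoylthiophen-3-yl stood gives a number 2 percentage points higher from compound 2 to compound 4 (within the scatter). At this position, then, a six-membered aromatic ring of carbon only and a five-membered aromatic ring carrying sulfur and chlorine cannot be told apart in this read-out, and compound 4 sits with compounds 2 and 3, well under compound 1 at 58.2%. Going by these compounds, whether a carboxylic acid in place of the carbamoyl group, or an amine in place of the hydroxy group, would keep compound 4's value remains open. Nothing available explains why these groups read alike.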